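The source may hold more compounds than are shown below. What is called first, only, known or untested is meant among the compounds shown, and "the series" means these compounds.

Compound 1 `Cn1cnc2c(Sc3ccc(F)cc3)ncnc21`: 6%
Compound 2 `Cn1c(-c2ccccc2)nc2c(Sc3ccc(F)cc3)ncnc21`: 9%
Compound 3 `Cn1c(-c2ccc([S+](C)[O-])cc2)nc2c(Sc3ccccc3)ncnc21`: 1%

In an assay on isolated protein for inhibition of Rho-associated protein kinase 1 (Homo sapiens), tested at 30 uM (a lower number here means less inhibition, a higher number more inhibition at the concentration tested (going by the name of the read-out)), compound 3 gives 1%, and its gaps to compound 1 and to compound 2 both lie within the scatter, so the three measured numbers stand together at the low end of the read-out. Compound 4 `Cn1c(-c2ccc([S+](C)[O-])cc2)nc2c(Sc3ccc(F)cc3)ncnc21` differs from compound 3 by fluoro in place of hydrogen on an aromatic carbon. Within the data shown here, no measured step introduces fluoro; the only measured step, a number 3 percentage points higher from compound 1 to compound 2 (within the scatter), concerns a different change and stayed within the scatter. Among the measured compounds shown here, since all three measured compounds show little inhibition and the one available step is flat, compound 4 is expected to give 3%, in the range -5% to 12%, with an expected step of a number 2 percentage points higher from compound 3 to compound 4 (within the scatter), not beyond the scatter.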

Compound 4, a percentage reported as inhibition, at one concentration (the size of the read-out at that concentration, not a potency): 0%
Beside the measured number, compound 4's estimate is 3 percentage points above it; the measured number falls inside the stated range.
By their numbers in this assay, from the lowest: compounds 4, 3, 1 and 2 (each within the scatter of the next).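

In this assay, among these compounds, the step of a number 1 percentage points lower from compound 3 to compound 4 (within the scatter) is the first reading of fluoro in place of hydrogen on this aromatic carbon, para to a large group, and it leaves the number at the low end of the read-out. The larger replacements on the core, the step of a number 9 percentage points lower from compound 2 to compound 4 (within the scatter) and the step of a number 6 percentage points lower from compound 1 to compound 4 (within the scatter), are just as flat. Nothing measured here offers a reason for this. The compounds shown leave open whether an amine or a carboxylic acid in place of the fluoro would move the number at all.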